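Clearance of compound 3 after a side-chain swap

The source may report more compounds than this note shows. Statements on the series, on what has been measured and on what is new or still open speak of the compounds shown alone.

Measured in an ADME assay on the whole organism for pharmacokinetics, with Rattus norvegicus as the target, at a dose of 3 mg/kg by the intravenous route; a higher number here means faster removal of the compound, a lower number slower removal:
Compound 1 `NC(=O)CN1CCC[C@H](Nc2nc(-c3c[nH]c4ncc(Cl)cc34)ncc2F)C1` gives 182 mL/min/kg
Compound 2 `C[C@]1(C(=O)O)CCCC[C@@H]1Nc1nc(-c2c[nH]c3ncc(Cl)cc23)ncc1F` gives 24 mL/min/kg

Of these two, compound 1 stands highest, and compound 2 lies lower by more than the scatter. Compound 3 `OC[C@H](O)CN1CCC[C@H](Nc2nc(-c3c[nH]c4ncc(Cl)cc34)ncc2F)C1` is compound 1 with a single change 1,2-dihydroxyethyl in place of carbamoyl on a saturated chain carbon bound to an amine nitrogen in a ring: 1,2-dihydroxyethyl in place of carbamoyl, on a saturated chain carbon bound to an amine nitrogen in a ring. Among the compounds with values here, no measured step covers this change, so only a small move towards a lower number, within the scatter, is expected (a 1.7-fold lower number from compound 1 to compound 3 (0.22 log units; within the scatter)). Compound 3 is estimated at 110 mL/min/kg, with an expected range from 45 mL/min/kg to 260 mL/min/kg in this assay, and the measurement is still to come.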

Compound 3, clearance: 56 mL/min/kg
Beside the measured number, compound 3's estimate is 2.0-fold (0.29 log units) above it; the measured number falls inside the stated range.
By their numbers in this assay, from the lowest: compound 2; then compound 3; then compound 1.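

In this assay there is a 3.3-fold lower number from compound 1 to compound 3 (0.51 log units; beyond the scatter) with 1,2-dihydroxyethyl in place of carbamoyl, the first single-place change shown. It establishes that the substituent on a saturated chain carbon bound to an amine nitrogen in a ring can alter clearance by more than the scatter. No measured evidence bears on why this happens.

The compounds shown leave open whether the opposite configuration at the defined stereocentre of the 1,2-dihydroxyethyl group gives the same number. They also leave open how a sulfonamide or a longer chain ending in one hydroxyl would compare at this place.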